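Replacing the pyridinyl amide substituent with allyl

A few compounds are considered here, and "the series" means these few. Any claim that something is new, unique, unknown or untested is made for them only; others in the source may bear on it.

Compound 2 `Cc1ccc(OCC(=O)N(Cc2cccs2)c2ccccn2)cc1` gives 200 nM in an assay on HEK293 cells for agonist activity at transient receptor potential cation channel subfamily M member 8 (Homo sapiens), read by fluorescence and calcium flux, with a stated time of 15 min; on this read-out lower numbers stand for an effect already at smaller amounts and higher numbers for an effect only at larger amounts of compound. Of the two numbers recorded in this assay, it is the lowest; the only other, that of compound 1 `CCN(Cc1cccnc1)C(=O)COc1ccc(C)cc1` at 15400 nM, lies beyond the scatter above it. Compound 3 `CCN1C(=O)C(Oc2ccc(C)cc2)C1c1cccs1` is recorded in this assay only as "active" (no number reported), without a number. Compound 4 `C=CCN(Cc1cccs1)C(=O)COc1ccc(C)cc1` remains to be measured. It differs from compound 2 in one place: allyl in place of pyridin-2-yl on an amide-type nitrogen. Among the measured compounds shown here, no pair of measured compounds shows this change, so its size is not known from the series. The pyridinyl-free amide of compound 1 carries the higher number, and a loss beyond the scatter is therefore expected, estimated as a 15-fold higher number from compound 2 to compound 4 (1.18 log units; beyond the scatter). Compound 4 is expected to give about 3000 nM, within 500 nM to 20000 nM.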

Compound 4, half-maximal effective concentration: 20 nM
Beside the measured number, compound 4's estimate is 150-fold (2.18 log units) above it; measured number outside the range, below it.
By their numbers in this assay, from the lowest: compound 4; then compound 2; then compound 1.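

Among the compounds shown here, at the amide-type nitrogen, a ring is not required for activity in this assay: allyl, which has no ring and no hydrogen-bond acceptor, replaces pyridin-2-yl with a 10-fold lower number from compound 2 to compound 4 (1.00 log units; beyond the scatter), the first measured step at this position. The gain therefore does not depend on the pyridin-2-yl ring or its ring nitrogen. Nothing measured here accounts for the size of this step.

On these data alone, the role of the allyl double bond remains open, as a saturated propyl group would test it. A longer chain such as butyl, or a chain ending in an amine, would show how far this position tolerates other groups.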